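This account rests on a few compounds, and the source may have more. Where it says the series, first, only, none or still open, it means among the compounds named here.

Compounds measured so far:
- compound 1 `Cc1ccc(S(=O)(=O)Nc2ccc3oc(-c4ccccc4)nc3c2)cc1`: > 63000 nM, a limit of the assay
- compound 2 `COc1cccc(S(=O)(=O)Nc2ccc3oc(-c4ccccc4)nc3c2)c1`: > 63000 nM, a limit of the assay
- compound 3 `O=S(=O)(Nc1ccc2oc(-c3ccccc3)nc2c1)c1cccc(Cl)c1`: > 63000 nM, a limit of the assay

In an assay on isolated protein for inhibition of malate dehydrogenase, mitochondrial (Sus scrofa), with stated times of 45 min and 30 min (on this read-out lower numbers stand for stronger inhibition and higher numbers for weaker inhibition), compound 1 gives > 63000 nM, which is a limit and not a number. Compound 2 likewise gives only the limit > 63000 nM. On these data alone, compound 3 also stands at a limit, > 63000 nM, so its true value is unknown beyond that. All three measured values sit at the same limit, (the limit of > 63000 nM in this assay, at which 3 of the 3 values shown sit), and every step among them is therefore unreadable: a step that the two limits leave unreadable from compound 1 to compound 2, a step that the two limits leave unreadable from compound 1 to compound 3 and a step that the two limits leave unreadable from compound 2 to compound 3.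

Compound 4 `O=S(=O)(Nc1ccc2oc(-c3ccccc3)nc2c1)c1ccccc1Cl` has not yet been measured in this assay. It differs from compound 3 by 2-chlorophenyl in place of 3-chlorophenyl on a sulfonyl sulfur. For the measured compounds named here, the measured steps that touch the chlorophenyl group, from compound 1 to compound 3 and from compound 2 to compound 3, give no readable size, so no step of known size bears on this change. Going by the values given here, with every value so far at the limit, compound 4 is expected to remain there as well, and the step that the limit leaves unreadable from compound 3 to compound 4 is expected to carry no readable direction. Compound 4 is estimated at 100000 nM, within 40000 nM to 400000 nM.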

Compound 4, half-maximal inhibitory concentration: > 63000 nM
Compound 4 ended at the assay's limit; the forecaster's own chance of this, stated with the estimate: 85%; the middle value lies beyond the limit too.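

The steps from compound 1, compound 2 and compound 3 to compound 4 cannot be read, because each of these compounds gives a limit and not a number: the limit of > 63000 nM in this assay, at which 4 of the 4 values shown sit.

What these compounds leave open is how far their true values in this assay lie past that limit, and whether changing the group on the sulfonyl sulfur alters them at all.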